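Swapping Bromo for Methoxy: What One Measured Step Suggests

This account rests on a few compounds, and the source may have more. Where it says the series, first, only, none or still open, it means among the compounds named here.

Of the compounds shown here, two with a shared core have been measured so far. In a functional assay on K562 cells (Homo sapiens) for cytotoxicity, read by trypan blue exclusion, with a stated time of 96 h (on this read-out lower numbers stand for stronger inhibition and higher numbers for weaker inhibition), compound 1 `COC(=O)C(Nc1cc(CS(=O)(=O)/C=C/c2c(OC)cc(OC)cc2OC)ccc1OC)c1ccc(F)cc1` gives 800 nM and compound 2 `COC(=O)C(Nc1cc(CS(=O)(=O)/C=C/c2c(OC)cc(OC)cc2OC)ccc1OC)c1ccc(Br)cc1` gives 200 nM, so compound 2 holds the lower of the two numbers and is the stronger inhibitor of this pair.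

The next structure, compound 3 `COC(=O)C(Nc1cc(CS(=O)(=O)/C=C/c2c(OC)cc(OC)cc2OC)ccc1OC)c1ccc(OC)cc1`, differs from compound 2 in one place: methoxy in place of bromo on an aromatic carbon, para to a large group (methoxy in place of bromo on an aromatic carbon).

Among the measured compounds shown here, only one measured step bears on this change: a 4.0-fold lower number from compound 1 to compound 2 (0.60 log units; beyond the scatter), with bromo in place of fluoro on an aromatic carbon. That step lies beyond the scatter and counts as modest, so the number in this assay does respond to a swap of this kind. For the measured compounds named here, no measured compound carries methoxy, however, so the data give no direct guide to it.

A modest move away from the low number of compound 2 seems the likeliest outcome. The expected step is a 2.3-fold higher number from compound 2 to compound 3 (0.35 log units; beyond the scatter). For compound 3 the estimated value is 450 nM, with an expected range of 130 nM to 1400 nM.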

Compound 3, half-maximal inhibitory concentration: 150 nM
Beside the measured number, compound 3's estimate is 3.0-fold (0.48 log units) above it; the range from low to high includes it.
By their numbers in this assay, from the lowest: compounds 3 and 2 (each within the scatter of the next); then compound 1.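

In this assay, the change from bromo to methoxy on this aromatic carbon gives a 1.3-fold lower number from compound 2 to compound 3 (0.12 log units; within the scatter) and so leaves the two compounds indistinguishable on this read-out, even though methoxy has two heavy atoms and a hydrogen-bond acceptor while bromo has one heavy atom and no acceptor. The change from fluoro to methoxy gives a 5.3-fold lower number from compound 1 to compound 3 (0.73 log units; beyond the scatter) and now, with the earlier step from fluoro to bromo, compound 1 stands apart from both compound 2 and compound 3, with the higher number. So this position does not respond to every swap in the same way, since one change moves the number beyond the scatter and the other does not, and nothing measured here accounts for that difference.

As far as these compounds go, what remains open is whether this level can be kept or improved with a quite different group at this place, such as an amine, a carboxylic acid or a longer chain such as butoxy. It is also unclear whether a plain hydrogen here would sit nearer to compound 1 or to the other two compounds.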